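Oxadiazole azetidine series: amide to urea step

The compounds below may be only part of what the source reports. "The series", "measured", "known", "first", "only" and "open" are said of these compounds alone.

Measured so far:
compound 1 `O=C(c1ccc(F)cc1)N1CC(c2nc(-c3cccc(Cl)c3)no2)C1`, 4000 nM
compound 2 `Cc1cccc(-c2noc(C3CN(C(=O)C4CCC(C(F)(F)F)CC4)C3)n2)c1`, > 10000 nM
compound 3 `O=S(=O)(c1ccc(Cl)cc1)N1CC(c2nc(-c3cccc(Cl)c3)no2)C1`, 170 nM

In an assay on HEK293 cells for negative allosteric modulation of metabotropic glutamate receptor 5 (Homo sapiens), read by FLIPR (on this read-out lower numbers stand for stronger inhibition and higher numbers for weaker inhibition), compound 1 gives 4000 nM, the highest of the two numbers reported. Compound 3 gives 170 nM in this assay, a lower number beyond the usual scatter. For compound 2 this assay reports only a limit, > 10000 nM; see (the limit of > 10000 nM in this assay, at which 1 of the 3 values shown sits).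

Compound 4 `COC1CCCN(C(=O)N2CC(c3nc(-c4cccc(Cl)c4)no3)C2)C1` is not yet measured. It differs from compound 1 in one place: 3-methoxypiperidin-1-yl in place of 4-fluorophenyl on a carbonyl carbon. The shared core and the 3-chlorophenyl part stay as in compound 1; the carbonyl carbon now carries a 3-methoxypiperidin-1-yl group.

Of the two compounds with a non-aromatic group on the carbonyl carbon, compound 2 sits at the limit, while compound 1 with its aromatic group has a number. The expected step from compound 1 to compound 4 in this assay is a 2.0-fold higher number from compound 1 to compound 4 (0.30 log units; within the scatter), toward a higher number. Compound 4 is estimated at 8000 nM in this assay, with a range from 2500 nM to 25000 nM, and a fair chance of a limit only.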

Compound 4, half-maximal inhibitory concentration: 1830 nM
The estimate for compound 4 lay 4.4-fold (0.64 log units) above the measured number; the whole stated range lies above it.
By their numbers in this assay, from the lowest: compound 3; then compound 4; then compound 1. At a limit, above all of these: compound 2.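

In this assay, the carbonyl carbon whose other neighbour is the amide-type nitrogen in a ring accepts a non-aromatic ring without loss: the change to 3-methoxypiperidin-1-yl gives a 2.2-fold lower number from compound 1 to compound 4 (0.34 log units; beyond the scatter). On this single pair, then, a six-membered aromatic ring of carbon only is not needed at this place to keep a measured number in this assay. No measured property in hand bears on why the number falls, and the step alone gives no reason for it.

The compounds shown leave open whether the methoxy group contributes to the step, which unsubstituted piperidin-1-yl or morpholin-4-yl on the same carbonyl carbon would test. Also open, going by these compounds, is whether an open-chain amine such as dimethylamino at this place would hold the number of compound 4.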